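This account rests on a few compounds, and the source may have more. Where it says the series, first, only, none or still open, it means among the compounds named here.

In an ADME assay on HeLa cells (Homo sapiens) for cytotoxicity, read by MTT assay (on this read-out lower numbers stand for stronger inhibition and higher numbers for weaker inhibition), compound 1 (`CCN(CC)C(=O)CCC(=O)Oc1ccc(C[C@H]2C(=O)OC[C@@H]2Cc2ccc(OC)c(OC)c2)cc1OC`) gives 213000 nM and compound 2 (`CCN(CC)C(=O)COc1ccc(C[C@H]2C(=O)OC[C@@H]2Cc2ccc(OC)c(OC)c2)cc1OC`) gives 188000 nM while compound 3 (`COc1ccc(C[C@H]2COC(=O)[C@@H]2Cc2ccc(OC(=O)CCC(=O)N3CCCCC3)c(OC)c2)cc1OC`) gives 128000 nM within the scatter of both. Compound 4 (`COc1ccc(C[C@H]2COC(=O)[C@@H]2Cc2ccc(OCC(=O)N3CCOCC3)c(OC)c2)cc1OC`) departs from compound 3 by one change on an oxygen on an aromatic ring (a group of 9 heavy atoms (6 carbon, 1 nitrogen, 2 oxygen; one six-membered non-aromatic ring with 2 hetero atoms) in place of a group of 12 heavy atoms (9 carbon, 1 nitrogen, 2 oxygen; one six-membered non-aromatic ring with 1 hetero atom), on an oxygen on an aromatic ring), where ((morpholin-4-yl)carbonyl)methyl enters. The measured steps that bear on it all lie within the scatter: one exchange on that oxygen (a 1.1-fold lower number from compound 1 to compound 2 (0.05 log units; within the scatter)), piperidin-1-yl in place of diethylamino on a carbonyl carbon (a 1.7-fold lower number from compound 1 to compound 3 (0.22 log units; within the scatter)) and a second exchange on that oxygen (a 1.5-fold lower number from compound 2 to compound 3 (0.17 log units; within the scatter)). The expected result is therefore no step beyond the scatter in this assay, with an estimate of a 1.3-fold higher number from compound 3 to compound 4 (0.10 log units; within the scatter) for its size. Compound 4 is expected at 160000 nM (estimated range 80000 nM to 320000 nM).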

Compound 4, half-maximal inhibitory concentration: >= 600000 nM
Compound 4 was reported as a limit (the forecaster's own chance of this, stated with the estimate: 10%); at least 3.7-fold (0.57 log units) between middle value and limit.
By their numbers in this assay, from the lowest: compounds 3, 2 and 1 (each within the scatter of the next). At a limit, above all of these: compound 4.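

In this assay, the exchange on an oxygen on an aromatic ring moves the number beyond the scatter once ((morpholin-4-yl)carbonyl)methyl enters, giving an at least 4.6-fold higher number from compound 3 to compound 4 (0.67 log units; beyond the scatter), an at least 3.1-fold higher number from compound 2 to compound 4 (0.50 log units; beyond the scatter) and an at least 2.8-fold higher number from compound 1 to compound 4 (0.44 log units; beyond the scatter). The earlier exchanges at this place all stayed within the scatter. Compound 4 is reported only as a limit, so these steps fix no exact size: the limit of >= 600000 nM in this assay, at which 1 of the 4 values shown sits.

As far as these compounds go, how far the true value of compound 4 lies past that limit stays open. So does whether a piperazin-1-yl or a piperidin-1-yl on the same carbonylmethyl chain would behave like morpholin-4-yl.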